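Chloro in place of cyano: clearance notes

The source may report more compounds than this note shows. Statements on the series, on what has been measured and on what is new or still open speak of the compounds shown alone.

In an in vitro ADME assay on microsomes from liver (Homo sapiens) for metabolic stability (a higher number here means faster removal of the compound, a lower number slower removal), compound 1 `COCc1ccccc1C1Cc2nccn2C1` gives < 7 mL.min-1.g-1, a limit of the assay and not a number. Compound 2 `N#Cc1ccccc1C1Cc2nccn2C1` gives < 7 mL.min-1.g-1, also only a limit. Within the data shown here, the sole measured step, a step that the two limits leave unreadable from compound 1 to compound 2, therefore has no size to carry forward, and the record stops at the limit of < 7 mL.min-1.g-1 in this assay, at which 2 of the 2 values shown sit. Compound 3 `Clc1ccccc1C1Cc2nccn2C1` differs from compound 2 by chloro in place of cyano on an aromatic carbon. The change is expected to be modest, though the data fix no direction firmly. The estimated step is an at least 1.1-fold higher number from compound 2 to compound 3 (0.05 log units; that floor lies within the scatter). For compound 3 the expected value is 8 mL.min-1.g-1, with an estimated range of 5 mL.min-1.g-1 to 20 mL.min-1.g-1.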

Compound 3, intrinsic clearance in microsomes: 18 mL.min-1.g-1
Beside the measured number, compound 3's estimate is 2.3-fold (0.35 log units) below it, within the range that was stated.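

In this assay, this aromatic carbon now gives readable steps: chloro in place of cyano gives an at least 2.5-fold higher number from compound 2 to compound 3 (0.41 log units; beyond the scatter), and chloro in place of methoxymethyl gives an at least 2.5-fold higher number from compound 1 to compound 3 (0.41 log units; beyond the scatter). The group at this position can therefore shift clearance beyond the scatter, which the earlier pair could not show. Both steps are floors and not full sizes: the limit of < 7 mL.min-1.g-1 in this assay, at which 2 of the 3 values shown sit.

The true size of each step remains unreadable, as does any gap between compound 1 and compound 2. Also open, from the compounds shown here alone, is whether an amine or a carboxylic acid on this aromatic carbon would give a number like that of compound 3 or stay at the limit.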